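Hydroxyalkyl imine variant of a weak coumarin myosin-2 series

This account rests on a few compounds, and the source may have more. Where it says the series, first, only, none or still open, it means among the compounds named here.

Measured so far:
compound 1, `C/C(=N\CC(C)C)c1c(O)c2ccccc2oc1=O`: 34000 nM
compound 2, `C/C(=N\CC(C)C)c1c(O)c2ccccc2[nH]c1=O`: >= 100000 nM
compound 3, `CC/C(=N\Cc1ccccc1)c1c(O)c2ccccc2oc1=O`: >= 100000 nM

All three were tested in an assay on isolated protein for inhibition of myosin-2 (Bos taurus), read by spectrophotometry, with a stated time of 24 min; on this read-out higher numbers stand for weaker inhibition and lower numbers for stronger inhibition. In this assay compound 1 gives 34000 nM, the only numerical result in the set, and it marks compound 1 as a weak inhibitor. For compound 2 this assay returns only a limit, >= 100000 nM. For compound 3 the result is likewise a limit, >= 100000 nM. The remaining two results are thus summarised by the limit of >= 100000 nM in this assay, at which 2 of the 3 values shown sit, so compound 1 is the sole reference point with a number, and nothing in the set is ordered against it.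

Within the data shown here, no two measured compounds differ in a single place, so no measured step exists to anchor a new change.

Compound 4, `C/C(=N\CCCO)c1c(O)c2ccccc2oc1=O`, has not been measured. Its difference from compound 1 is 2-hydroxyethyl in place of isopropyl on a saturated chain carbon bound to a double-bonded nitrogen. The change keeps the chain length but swaps a branched alkyl end for a hydroxyl-bearing one. With compound 1 at 34000 nM as the only numerical anchor in the set, the expected step in this assay is a 1.8-fold higher number from compound 1 to compound 4 (0.25 log units; within the scatter), a modest weakening not clearly beyond the scatter. It is possible that compound 4 itself returns no number in this assay. The estimate for compound 4 in this assay is 60000 nM, between 20000 nM and 200000 nM.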

Compound 4, half-maximal inhibitory concentration: 37000 nM
Estimate against measurement, compound 4: 1.6-fold (0.21 log units) above; the range from low to high includes it.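

In this assay, among these compounds, 2-hydroxyethyl in place of isopropyl on a saturated chain carbon bound to a double-bonded nitrogen gives a 1.1-fold higher number from compound 1 to compound 4 (0.04 log units; within the scatter), and this is the first measured step in the set between compounds that differ in one place. At this place, then, a hydroxyl-bearing end and a branched alkyl end cannot be told apart in this read-out, and the added hydrogen-bond donor and acceptor counted for the entering group bring no change that can be read. The results for compound 2 and compound 3 remain limits and not numbers, so the numerical part of the set still rests on a single pair: the limit of >= 100000 nM in this assay, at which 2 of the 4 values shown sit.

One step within the scatter leaves open whether any group at this place can move the number beyond the scatter, for instance an amine or a carboxylic acid at the end of the chain, or a longer chain. It also leaves open whether the match between the hydroxyl-bearing end and the branched alkyl end would hold on a core other than that of compound 1.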